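The compounds below may be only part of what the source reports. "The series", "measured", "known", "first", "only" and "open" are said of these compounds alone.

Compound 1 `Cc1cc(Nc2cc(-c3ccccc3)[nH]n2)n2nc(SCc3ccc(F)cc3)nc2n1` is the starting point. In a functional assay on PC-9 cells (Homo sapiens) for inhibition, read by MTT assay, with a stated time of 72 h (a higher number here means a weaker inhibitor, a lower number a stronger inhibitor), compound 1 gives 8110 nM, which is the only plain number shown for this series. Compound 2 `Cc1cc(Nc2cc(-c3ccccc3)[nH]n2)n2nc(SCC3CCCCC3)nc2n1` carries a cyclohexyl in place of the 4-fluorophenyl on the saturated chain carbon bound to the sulfur. In this assay compound 2 reaches only > 50000 nM, a limit of the assay and not a measured number. The step from compound 1 to compound 2 therefore reads an at least 6.1-fold higher number from compound 1 to compound 2 (0.78 log units; beyond the scatter), in line with the limit of > 50000 nM in this assay, at which 1 of the 2 values shown sits.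

Compound 3 `C#CCSc1nc2nc(C)cc(Nc3cc(-c4ccccc4)[nH]n3)n2n1` is not yet measured. It differs from compound 1 as follows: ethynyl in place of 4-fluorophenyl on a saturated chain carbon bound to a sulfur. Going by the values given here, the single measured step that touches the same place, an at least 6.1-fold higher number from compound 1 to compound 2 (0.78 log units; beyond the scatter), shows that exchanging the 4-fluorophenyl for a non-aromatic group at this carbon produces a weaker inhibitor. Ethynyl is also a non-aromatic group, so a shift towards a higher number is expected for compound 3, though its size is uncertain with only one comparison. The expected step is a 2.7-fold higher number from compound 1 to compound 3 (0.43 log units; beyond the scatter), giving an estimate for compound 3 of 22000 nM, within a range from 5000 nM to 80000 nM.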

Compound 3, half-maximal inhibitory concentration: > 50000 nM
Compound 3: a limit, no number (the forecaster's own chance of this, stated with the estimate: 30%); at least 2.2-fold (0.35 log units) between middle value and limit.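

The new result shows that the loss in this assay is not tied to the cyclohexyl alone: replacing 4-fluorobenzyl with propargyl gives an at least 6.1-fold higher number from compound 1 to compound 3 (0.78 log units; beyond the scatter). Going by these compounds alone, two quite different groups on the saturated chain carbon bound to the sulfur, a saturated ring and an ethynyl, therefore both leave the 4-fluorophenyl of compound 1 as the only group here with a plain number, and the two results end at the same assay limit: the limit of > 50000 nM in this assay, at which 2 of the 3 values shown sit. Compound 2 and compound 3 both stand at a limit, so the step between them cannot be read and cyclohexyl and ethynyl cannot be ranked against each other.

The compounds shown leave open whether the aromatic ring or its fluorine is what counts at this carbon, a question that a plain phenyl or a 4-methoxyphenyl would help to separate. They also leave open whether any group at this place can give a lower number than compound 1 does, 8110 nM.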